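Isobutyl to Benzyl on a Second Core

A few compounds are considered here, and "the series" means these few. Any claim that something is new, unique, unknown or untested is made for them only; others in the source may bear on it.

Compound 1, `CC(=O)Nc1cc(OCC(C)C)nc(SCc2ccccc2)n1`, in a functional assay on HT-29 cells (Homo sapiens) for antiproliferative activity, read by MTT assay, with a stated time of 72 h (a higher number here means a weaker inhibitor of growth, a lower number a stronger inhibitor of growth), gives 35700 nM.
Compound 2, `CC(=O)Nc1cc(OCc2ccccc2)nc(SCc2ccccc2)n1`, in this assay gives 65800 nM.
Compound 3, `CC(C)Cn1c(SCc2ccccc2)nc(N)cc1=O`, in this assay gives only a limit, > 100000 nM.

Compounds 1 and 2 share one core and differ in a single place: phenyl in place of isopropyl on a saturated chain carbon bound to an oxygen on an aromatic ring. That change gave a 1.8-fold higher number from compound 1 to compound 2 (0.27 log units; within the scatter), so the growth-inhibition values of compound 1 and compound 2 cannot be told apart. Compound 3 carries a different core; the difference between the two cores is not broken down here. The value of compound 3 is not a number but a limit of the assay, the one at which (the limit of > 100000 nM in this assay, at which 1 of the 3 values shown sits).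

Compound 4, `Nc1cc(=O)n(Cc2ccccc2)c(SCc2ccccc2)n1`, has not been measured. It stands to compound 3 as compound 2 stands to compound 1: phenyl in place of isopropyl on a saturated chain carbon bound to an aromatic nitrogen. This is the same kind of change as the earlier one, not the same change, for the saturated chain carbon is here bound to an aromatic nitrogen and there to an oxygen on an aromatic ring. Seen one bond further out, both read isobutyl to benzyl.

Resting on a 1.8-fold higher number from compound 1 to compound 2 (0.27 log units; within the scatter), compound 4 is expected to move by a step that the limit leaves unreadable from compound 3 to compound 4. Compound 3 sits at the limit, and compound 4 is expected most likely to return only a limit as well. In this assay compound 4 is estimated at about 150000 nM, with 60000 nM and 400000 nM as the ends of the expected range.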

Compound 4, concentration for 50% growth inhibition: 100000 nM
For compound 4 the middle estimate is 1.5-fold (0.18 log units) above the measured one; measured number inside the range.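

The isobutyl to benzyl change can now be set side by side on two cores: the same change on two cores in this assay, a 1.8-fold higher number (0.27 log units; within the scatter) from compound 1 to compound 2 and a number no higher (the limit leaves the size open) from compound 3 to compound 4; the limit leaves it open whether they differ. In this assay the entry for compound 3 is not a number but a limit of the assay, > 100000 nM. Within the data shown here, on this second core the change gave a number no higher from compound 3 to compound 4 (the limit leaves the size open), so the step cannot be read and the pair shows neither that the change carries over from one core to the other nor that it behaves differently there; what stands firm is only that compound 1 and compound 2, on the first core, cannot be told apart, and that compound 4 gives 100000 nM, a value that sets no size for the change without a number for compound 3.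

Sizing the step on the second core would take a partner for compound 4 whose value falls clear of the limit, and the compounds shown hold no such pair. They also leave open what other groups would do in this place on either core, for example an amine or a carboxylic acid at the end of the chain, or a longer chain in place of the isobutyl or the benzyl.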